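The source may hold more compounds than are shown below. What is called first, only, known or untested is meant among the compounds shown, and "the series" means these compounds.

Measured in a functional assay on MCF7 cells (Homo sapiens) for cytotoxicity, read by sulforhodamine B assay, with a stated time of 48 h, in the presence of a further agent that is not named here; a higher number here means a weaker inhibitor of growth, a lower number a stronger inhibitor of growth:

Compound 1 `Cc1nn(-c2ccccc2)c(Oc2ccc(-c3nc4cc([N+](=O)[O-])ccc4[nH]3)cc2)c1/C=N/NC(N)=O`: 50 nM
Compound 2 `COc1ccc(N/N=C/c2c(C)nn(-c3ccccc3)c2Oc2ccc(-c3nc4cc(C(N)=O)ccc4[nH]3)cc2)cc1`: > 100000 nM (a limit of the assay, not a number)
Compound 3 `Cc1nn(-c2ccccc2)c(Oc2ccc(-c3nc4cc(C(N)=O)ccc4[nH]3)cc2)c1/C=N/Nc1ccc([N+](=O)[O-])cc1`: "not determined" (no result reported)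

Compound 3 has no place on the scale of this assay, because no result was reported for it and its entry reads "not determined" (no result reported). Among the measured compounds shown here, only two other compounds offer any orientation. Compound 1 gives a real number of 50 nM, a strong inhibition of growth. Compound 2 gives > 100000 nM, and this is a limit.

One change leads onward to compound 4 `Cc1nn(-c2ccccc2)c(Oc2ccc(-c3nc4cc(C(N)=O)ccc4[nH]3)cc2)c1/C=N/NC(N)=O`: carbamoyl in place of 4-nitrophenyl on an amine nitrogen. In words, carbamoyl stands in place of 4-nitrophenyl on an amine nitrogen. Cut one bond further out, the same change reads (4-nitrophenyl)amino to ureido.

With no number for compound 3, the data cannot size this step. A large step towards stronger growth inhibition is still the expectation, because compound 1 with the same ureido gives 50 nM. That support is thin, so the expectation stays loose and the range must be wide.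

For compound 4, the concentration for half-maximal growth inhibition is estimated at 2000 nM, with an expected range of 100 nM to 50000 nM.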

Compound 4, concentration for 50% growth inhibition: > 100000 nM
Compound 4 ended at the assay's limit; the forecaster's own chance of this, stated with the estimate: 20%; middle value at least 50-fold (1.69 log units) away from the limit.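

In this assay compound 4 gives > 100000 nM, and this is a limit of the assay, not a number. Its real news lies in the comparison with compound 1, since the two carry the same ureido and differ only on an aromatic carbon of the shared core, where carbamoyl stands in place of nitro: the result is an at least 2000-fold higher number from compound 1 to compound 4 (3.30 log units; beyond the scatter), so in this pair ureido alone does not secure growth inhibition, and the group on that aromatic carbon decides the outcome. Compound 2 and compound 4 both end at the limit, so the step between them cannot be read, and neither 4-methoxyphenyl nor carbamoyl on the amine nitrogen can be ranked: the limit of > 100000 nM in this assay, at which 2 of the 4 values shown sit.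

The compounds shown do not tell whether a nitrile, an amine or a carboxylic acid on that aromatic carbon would stay close to compound 1, which gives 50 nM, or fall away as carbamoyl does. They also leave open how much of the strength of compound 1 would survive if 4-methoxyphenyl or 4-nitrophenyl replaced the carbamoyl on the amine nitrogen while nitro stayed in place.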